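Cyclopropyl replacing allyl on the ring nitrogen of compound 2

The compounds below may be only part of what the source reports. "The series", "measured", "known", "first", "only" and "open" are said of these compounds alone.

Measured so far in a functional assay on K562 cells (Homo sapiens) for cytotoxicity, read by MTT assay, with a stated time of 48 h; a lower number here means a stronger inhibitor, a higher number a weaker inhibitor:
Compound 1, `[O-][n+]1nc(NC2CCCCC2)[n+]([O-])c2ccccc21`: 2600 nM
Compound 2, `C=CCNc1n[n+]([O-])c2ccccc2[n+]1[O-]`: 11200 nM
Compound 3, `[O-][n+]1nc(NCc2ccccc2)[n+]([O-])c2ccccc21`: 1900 nM

Compound 2 gives the highest number of the three, with compound 1 nearest and compound 3 furthest, both steps beyond the scatter. Compound 4, `[O-][n+]1nc(NC2CC2)[n+]([O-])c2ccccc21`, differs from compound 2 by cyclopropyl in place of allyl on a nitrogen on an aromatic ring. Going by the values given here, two steps bear on this. The step of a 4.3-fold higher number from compound 1 to compound 2 (0.63 log units; beyond the scatter) shows that a larger saturated ring on the same nitrogen sits well below compound 2; the step of a 5.9-fold lower number from compound 2 to compound 3 (0.77 log units; beyond the scatter) shows that a ring on the chain also lowers the number. Cyclopropyl keeps the three heavy atoms of allyl but carries a ring, so a lowering smaller than either step is expected, a 1.9-fold lower number from compound 2 to compound 4 (0.27 log units; within the scatter). Compound 4 is therefore estimated at 6000 nM, between 2500 nM and 14000 nM.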

Compound 4, half-maximal inhibitory concentration: 6600 nM
For compound 4 the middle estimate is 1.1-fold (0.04 log units) below the measured one; measured number inside the range.
By their numbers in this assay, from the lowest: compounds 3 and 1 (each within the scatter of the next); then compounds 4 and 2 (each within the scatter of the next).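

In this assay cyclopropyl in place of allyl on this nitrogen gives a 1.7-fold lower number from compound 2 to compound 4 (0.23 log units; within the scatter) and so does not separate the two groups, which shows that a three-membered ring alone does not bring the number down to that of compound 3 or compound 1. Cyclopropyl in place of cyclohexyl gives a 2.5-fold higher number from compound 1 to compound 4 (0.40 log units; beyond the scatter) and this separation shows that, among the rings on this nitrogen, the choice of ring counts. No measurement on hand explains either step.

Still open, going by these compounds, is where cyclobutyl or cyclopentyl on this nitrogen would fall between compound 4 and compound 1. Also open, on these data alone, is whether a saturated propyl chain would stay with allyl and cyclopropyl.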